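Bromo in Place of Hydrogen on a Bis-methoxyphenyl Core

The source may hold more compounds than are shown below. What is called first, only, known or untested is meant among the compounds shown, and "the series" means these compounds.

Measured compounds:
compound 1, `COc1ccc(C2CC(c3ccccc3)=NN2C2=NC(=O)/C(=C3\C(=O)Nc4ccc(Br)cc43)S2)cc1`, 360 nM
compound 2, `COc1ccc(C2=NN(C3=NC(=O)/C(=C4\C(=O)Nc5ccccc54)S3)C(c3ccc(OC)cc3)C2)cc1`, 100000 nM

The measurements come from a functional assay on cells (Cancer cell lines, Homo sapiens) for cytotoxicity, read by sulforhodamine B assay, with a stated time of 48 h; a lower number here means a stronger inhibitor of growth, a higher number a weaker inhibitor of growth. Compound 2 gives 100000 nM, the highest of the two numbers. Its nearest neighbour is compound 1, which in this assay gives 360 nM, a far lower number; the two compounds differ in more than one place, so their values alone show the gap and nothing more.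

Compound 3, `COc1ccc(C2=NN(C3=NC(=O)/C(=C4\C(=O)Nc5ccc(Br)cc54)S3)C(c3ccc(OC)cc3)C2)cc1`, has not yet been measured. It differs from compound 2 in one place: bromo in place of hydrogen on an aromatic carbon. Compound 1 also carries this bromo, and it stands well below compound 2 in this assay. Because of 360 nM for compound 1, the change to compound 3 is expected to lower the number by a large step, a 20-fold lower number from compound 2 to compound 3 (1.30 log units; beyond the scatter), well beyond the scatter. Compound 3 is therefore estimated at 5000 nM, with a range from 500 nM to 50000 nM.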

Compound 3, concentration for total growth inhibition: 380 nM
Compound 3: middle estimate off by 13-fold (1.12 log units), on the high side; the measured number lies below the stated range.
By their numbers in this assay, from the lowest: compounds 1 and 3 (each within the scatter of the next); then compound 2.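

In this assay, the gap between compounds that differed in more than one place can now be read as two single changes. Bromo in place of hydrogen on an aromatic carbon, in the six-membered ring of the fused system, gives a large step on the bis-methoxyphenyl core, a 260-fold lower number from compound 2 to compound 3 (2.42 log units; beyond the scatter). With the bromo present, the change that brings in methoxy gives a 1.1-fold higher number from compound 1 to compound 3 (0.02 log units; within the scatter), so that among these compounds only the bromo step lies beyond the scatter. Nothing given here explains the size of the bromo step.

From the compounds shown here alone, it remains open whether chloro, an amine or a carboxylic acid on that same aromatic carbon would give a step of similar size. Going by these compounds, it is also open whether the methoxy step would stay as small on a core without the bromo.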